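A few compounds are considered here, and "the series" means these few. Any claim that something is new, unique, unknown or untested is made for them only; others in the source may bear on it.

In a functional assay for inhibition, read by spectrophotometry, with a stated time of 20 min, tested at 3 mg/mL (a lower number here means a weaker effect, a higher number a stronger effect of the compound at the concentration tested), compound 1 `CC(=O)c1ccc(NC(=O)CN(C(=O)c2ccccc2)S(=O)(=O)c2ccc(C)cc2)cc1` gives 18.2% and compound 2 `CC(=O)c1ccc(NC(=O)CN(C(=O)c2ccccc2)S(=O)(=O)c2ccccc2)cc1` gives 40.7%; between them a number 22.5 percentage points higher from compound 1 to compound 2 (beyond the scatter). Compound 2 thus stands highest of the two numbers in this assay. Compound 3 `CC(=O)c1ccc(NC(=O)C(C(C)C)N(C(=O)c2ccccc2)S(=O)(=O)c2ccccc2)cc1` differs from compound 2 by isopropyl in place of hydrogen on a saturated chain carbon bound to an amide-type nitrogen and a carbonyl carbon. For the measured compounds named here, the only measured step concerns a change on an aromatic carbon, not on the saturated chain carbon, so no measured step bears on this change and there is nothing to rest a direction on. The expected step of a number 0.7 percentage points lower from compound 2 to compound 3 (within the scatter) is therefore none beyond the scatter. Compound 3 is estimated at 40% in this assay, ranging from 15% to 65%.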

Compound 3, a percentage reported as inhibition, at one concentration (the size of the read-out at that concentration, not a potency): 47.5%
Estimate against measurement, compound 3: 7.5 percentage points below; low and high end bracket the measured number.
By their numbers in this assay, from the lowest: compound 1; then compounds 2 and 3 (each within the scatter of the next).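

In this assay, for the compounds shown here, the saturated chain carbon bound to an amide-type nitrogen and a carbonyl carbon accepts isopropyl in place of hydrogen, with a number 6.8 percentage points higher from compound 2 to compound 3 (within the scatter) as the only reading at this position. The earlier step, on an aromatic carbon, gave no information on this carbon. Nothing available accounts for this result. Still open, going by these compounds, is whether an amine, a carboxylic acid or a longer chain on this carbon would keep the reading within the scatter of compound 2.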